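The source may report more compounds than this note shows. Statements on the series, on what has been measured and on what is new or still open speak of the compounds shown alone.

In an ADME assay (Homo sapiens) for protein binding, compound 1 `COC(=O)c1ccccc1-c1ccc(CNc2nccc(C)c2NC(=O)CC#N)cc1` gives 99% and compound 2 `COC(=O)C1=C(c2ccc(CNc3nccc(C)c3NC(=O)CC#N)cc2)CCCC1` gives 96%, which leaves compound 2 with the higher unbound fraction of the two measured compounds. Compound 3 `COC(=O)c1cccn1-c1ccc(CNc2nccc(C)c2NC(=O)CC#N)cc1` has not yet been measured. It carries 2-(methoxycarbonyl)-1H-pyrrol-1-yl in place of 2-(methoxycarbonyl)cyclohex-1-en-1-yl on an aromatic carbon. Going by the values given here, only one measured step bears on this change: a 4.0-fold higher unbound fraction from compound 1 to compound 2 (0.60 log units; beyond the scatter), on replacing 2-(methoxycarbonyl)phenyl with 2-(methoxycarbonyl)cyclohex-1-en-1-yl. Like compound 1, compound 3 has an aromatic ring in this group, though a five-membered one, so only part of that modest step is expected to reverse. The expected change is a 1.6-fold lower unbound fraction from compound 2 to compound 3 (0.20 log units; within the scatter), a smaller move toward a lower unbound fraction that may not clear the scatter. For compound 3, the estimated value is 97.5%, with an expected range of 94% to 99.3%.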

Compound 3, plasma protein binding in the Homo sapiens assay: 81%
For compound 3 the middle estimate is 7.6-fold (0.88 log units) (unbound fraction) below the measured one; measured number outside the range, below it.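

In the Homo sapiens assay the 2-(methoxycarbonyl)-1H-pyrrol-1-yl group at this place, para to a large group, brings a 4.8-fold higher unbound fraction from compound 2 to compound 3 (0.68 log units; beyond the scatter) and also a 19-fold higher unbound fraction from compound 1 to compound 3 (1.28 log units; beyond the scatter) when set against the 2-(methoxycarbonyl)phenyl group. An aromatic ring in this group therefore does not by itself hold binding high: compound 1 and compound 3 both carry one, yet compound 3 has the highest unbound fraction of the three. In a physicochemical assay for lipophilicity (a higher number here means a more lipophilic compound, a lower number a more polar compound), compound 2 gives 3 and compound 3 gives 2.4 so the change from the cyclohexenyl group to the pyrrole also gives a less lipophilic compound, and this may be part of the reason for the freer compound: the measured partition coefficient of compound 2, 3, and of compound 3, 2.4, a number 0.60 log units lower (beyond the scatter).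

The compounds shown do not separate the effect of the five-membered ring from that of its attachment through nitrogen, as a pyrrol-2-yl group joined through carbon would. Nor do they show whether the higher unbound fraction holds when a carboxylic acid or a primary amide stands in place of the methoxycarbonyl group.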